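The source may hold more compounds than are shown below. What is called first, only, known or untested is meant among the compounds shown, and "the series" means these compounds.

Three compounds that share one core have been measured in an ADME assay for permeability, using PAMPA, with a stated time of 4 h, at pH 5.5; on this read-out lower numbers stand for lower permeability and higher numbers for higher permeability:

- compound 1 `NCCCCN(C[C@H]1Cc2ncccc2CN1)[C@H]1CCCc2cccnc21`: 17 nm/s
- compound 2 `NC/C=C/CN(C[C@H]1Cc2ncccc2CN1)[C@H]1CCCc2cccnc21`: 2 nm/s
- compound 3 `CCN(CC)CCCCN(C[C@H]1Cc2ncccc2CN1)[C@H]1CCCc2cccnc21`: 3 nm/s

Compound 3 sits at the low end of this small set, in a pair that cannot be told apart: a 1.5-fold higher number from compound 2 to compound 3 (0.18 log units; within the scatter). The third compound stands clearly apart from that pair, and its chain also differs from theirs. One of the steps away from it is an 8.5-fold lower number from compound 1 to compound 2 (0.93 log units; beyond the scatter), but that change lies in the chain itself, so it says little here.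

The next compound is compound 4 `c1cnc2c(c1)CN[C@@H](CN(CCCCNC1CCOCC1)[C@H]1CCCc3cccnc31)C2`. It differs from compound 3 only at the end of the chain: (oxan-4-yl)amino in place of diethylamino on a saturated chain carbon, four bonds along the chain from an amine nitrogen. In words, (oxan-4-yl)amino replaces diethylamino on a saturated chain carbon, four bonds along the chain from an amine nitrogen.

The measured step that bears most directly on this change sits at the same place: a 5.7-fold lower number from compound 1 to compound 3 (0.75 log units; beyond the scatter). That step swaps amino for diethylamino, so it shows that this position can matter in this assay. Going by the values given here, no measured compound yet carries the (oxan-4-yl)amino group. Like diethylamino, however, it keeps a substituent on the nitrogen, which the amino group of compound 1 at 17 nm/s lacks. The expectation is therefore that compound 4 stays close to compound 3, with no change beyond the scatter and perhaps a slight rise.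

The expected step is a 1.3-fold higher number from compound 3 to compound 4 (0.12 log units; within the scatter).

For compound 4 the estimated value is 4 nm/s, with an expected range from 1.5 nm/s to 12 nm/s.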

Compound 4, apparent permeability: 2 nm/s
The estimate for compound 4 lay 2.0-fold (0.30 log units) above the measured number; measured number inside the range.
By their numbers in this assay, from the lowest: compounds 2, 4 and 3 (each within the scatter of the next); then compound 1.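

In this assay, the (oxan-4-yl)amino group in place of diethylamino gives a 1.5-fold lower number from compound 3 to compound 4 (0.18 log units; within the scatter), so a six-membered ring holding an oxygen, with 1 hydrogen-bond donor where diethylamino has 0, cannot be told apart from the two ethyl groups at this position. Compared with the plain amino end of compound 1, oxan-4-yl in place of hydrogen on the amine nitrogen gives an 8.5-fold lower number from compound 1 to compound 4 (0.93 log units; beyond the scatter), which is a second clear fall alongside a 5.7-fold lower number from compound 1 to compound 3 (0.75 log units; beyond the scatter), so two quite different substituents on this nitrogen both end up well under compound 1. Going by these compounds alone, the pattern has an exception, though: the step of no change at the digits printed from compound 2 to compound 4 (within the scatter) places compound 4 level with compound 2, which has a plain amino end on its unsaturated chain and still gives a low number, so a substituent on this nitrogen is not the only change that separates a compound from compound 1.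

No measurement shown gives a reason for any of these differences. Still open, going by these compounds, is whether a single methyl on this nitrogen, or an amide at the end of the chain, would stay with the low group or come closer to compound 1.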